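The source may report more compounds than this note shows. Statements on the series, on what has been measured and on what is new or still open speak of the compounds shown alone.

Measured so far:
compound 1 `CCN1CCN(c2cc(C(F)(F)F)nc(SCc3ccc(C(F)(F)F)cc3)n2)CC1` — 27200 nM
compound 2 `FC(F)(F)c1ccc(CSc2nc(N3CCN(c4ccccn4)CC3)cc(C(F)(F)F)n2)cc1` — > 50000 nM

Going by the values given here, in a functional assay on PC-3 cells (Homo sapiens) for inhibition, read by MTT assay, with a stated time of 72 h (on this read-out higher numbers stand for weaker inhibition and lower numbers for stronger inhibition), compound 1 gives the only number measured. Compound 2 gives only a limit of the assay, (the limit of > 50000 nM in this assay, at which 1 of the 2 values shown sits). Compound 3 `FC(F)(F)c1ccc(CSc2nc(SC3=NCCS3)cc(C(F)(F)F)n2)cc1` differs from compound 1 in one place: a group of 6 heavy atoms (3 carbon, 1 nitrogen, 2 sulfur; one five-membered non-aromatic ring with 2 hetero atoms) in place of a group of 8 heavy atoms (6 carbon, 2 nitrogen; one six-membered non-aromatic ring with 2 hetero atoms), on an aromatic carbon. Among the compounds with values here, the one measured step alters the same 4-ethylpiperazin-1-yl group and went an at least 1.8-fold higher number from compound 1 to compound 2 (0.26 log units; that floor lies within the scatter), ending at a limit. Within the data shown here, no measured step shows a change at this carbon lowering the number. For compound 3 a weak result, possibly again a limit, is expected, estimated at 40000 nM with a range from 15000 nM to 100000 nM, meaning an estimated step of a 1.5-fold higher number from compound 1 to compound 3 (0.17 log units; within the scatter).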

Compound 3, half-maximal inhibitory concentration: 40600 nM
Beside the measured number, compound 3's estimate is 1.0-fold (0.01 log units) below it; low and high end bracket the measured number.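

In this assay, the ring with two sulfur atoms in place of 4-ethylpiperazin-1-yl gives a 1.5-fold higher number from compound 1 to compound 3 (0.17 log units; within the scatter). This carbon therefore now carries two quite different groups with readable values that cannot be told apart, so losing the piperazine ring does not by itself separate them on this read-out. Compound 2 remains a limit rather than a number: the limit of > 50000 nM in this assay, at which 1 of the 3 values shown sits.

As far as these compounds go, whether any group at this carbon can lower the number clearly stays open. A primary amine or a carboxylic acid there would test this.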